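Solubility notes: aryl-piperazine replaced by isopropylpiperidine

The source may report more compounds than this note shows. Statements on the series, on what has been measured and on what is new or still open speak of the compounds shown alone.

For the measured compounds named here, compound 3 `COc1ccc2[nH]c(C(=O)N3CC(=O)N(Cc4ccccc4)[C@@H](CN4CCN(c5ccccn5)CC4)C3)cc2c1` is the only member of the set with a true number in a physicochemical assay for solubility, read by spectrophotometry, in phosphate buffer, with a stated time of 2 h, at pH 7.4; a lower number here means a less soluble compound, a higher number a more soluble compound; in this assay compound 3 gives 30200 nM. Compound 1 `COc1ccc2[nH]c(C(=O)N3CC(=O)N(Cc4ccccc4)[C@@H](CN4CCCC4)C3)cc2c1` sits at a limit of this assay, with compound 1 at > 25000 nM. Compound 2 `COc1ccc2[nH]c(C(=O)N3CC(=O)N(Cc4ccccc4)[C@@H](Cc4ccccn4)C3)cc2c1` also sits at a limit of this assay, compound 2 giving > 100000 nM. Going by the values given here, the one readable step is an at least 3.3-fold lower number from compound 2 to compound 3 (0.51 log units; beyond the scatter); the steps a step that the two limits leave unreadable from compound 1 to compound 2 and a step that the limit leaves unreadable from compound 1 to compound 3 stay unreadable because of the limit of > 100000 nM in this assay, at which 1 of the 3 values shown sits, and (the limit of > 25000 nM in this assay, at which 1 of the 3 values shown sits).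

Compound 4 `COc1ccc2[nH]c(C(=O)N3CC(=O)N(Cc4ccccc4)[C@@H](CN4CCC(C(C)C)CC4)C3)cc2c1` differs from compound 3 by 4-isopropylpiperidin-1-yl in place of 4-(pyridin-2-yl)piperazin-1-yl on a saturated chain carbon bound to a saturated ring carbon. No measured step exchanges the 4-(pyridin-2-yl)piperazin-1-yl group for a saturated ring alone, so the step of an at least 3.3-fold lower number from compound 2 to compound 3 (0.51 log units; beyond the scatter) bears on it only as the sole size shown, and the limits of compound 1 give no size. The expected step is a 1.5-fold lower number from compound 3 to compound 4 (0.18 log units; within the scatter), within the scatter in either direction. Compound 4 is expected at 20000 nM, in a range from 6000 nM to 60000 nM.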

Compound 4, solubility: 12000 nM
Beside the measured number, compound 4's estimate is 1.7-fold (0.22 log units) above it; measured number inside the range.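

In this assay, 4-isopropylpiperidin-1-yl in place of 4-(pyridin-2-yl)piperazin-1-yl gives a 2.5-fold lower number from compound 3 to compound 4 (0.40 log units; beyond the scatter). For the compounds shown here, this is the first step at this place, on a saturated chain carbon bound to a saturated ring carbon, with a true number at both ends, and it shows that the exchange of one six-membered non-aromatic ring group for another is readable here. Compound 4 has the lowest number of the four, with an at least 8.3-fold lower number from compound 2 to compound 4 (0.92 log units; beyond the scatter) and an at least 2.0-fold lower number from compound 1 to compound 4 (0.31 log units; beyond the scatter); both steps start from a value that is a limit and not a number.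

The steps from compound 1 to compound 2 and from compound 1 to compound 3 still cannot be read. The change from compound 3 to compound 4 alters the ring and its substituent together, and a 4-isopropylpiperazin-1-yl group at this place would separate the two.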